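A few compounds are considered here, and "the series" means these few. Any claim that something is new, unique, unknown or untested is made for them only; others in the source may bear on it.

Measured in a functional assay on HeLa cells (Homo sapiens) for inhibition, read by CCK-8 assay, with a stated time of 48 h (on this read-out lower numbers stand for stronger inhibition and higher numbers for weaker inhibition), so far:
Compound 1 `O=C(NCCNS(=O)(=O)c1ccc(-c2ccccc2O[C@H]2CC[C@H](O)CC2)s1)Nc1cc(C(F)(F)F)cc(C(F)(F)F)c1` gives > 20000 nM (a limit of the assay, not a number)
Compound 2 `O=C(NCCNS(=O)(=O)c1ccc(-c2ccccc2O[C@H]2CC[C@@H](O)CC2)s1)Nc1cc(C(F)(F)F)cc(C(F)(F)F)c1` gives 14100 nM (a number)
Compound 3 `Nc1ccc(Oc2ccccc2-c2ccc(S(=O)(=O)NCCNC(=O)Nc3cc(C(F)(F)F)cc(C(F)(F)F)c3)s2)cc1` gives > 20000 nM (a limit of the assay, not a number)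

Compound 3 therefore has no exact place on the scale. It sits at the limit of > 20000 nM in this assay, at which 2 of the 3 values shown sit, and could lie anywhere beyond that mark.

The next compound, compound 4 `O=C(NCCNS(=O)(=O)c1ccc(-c2ccccc2OCc2ccccc2)s1)Nc1cc(C(F)(F)F)cc(C(F)(F)F)c1`, differs from compound 3 in one place: benzyl in place of 4-aminophenyl on an oxygen on an aromatic ring.

The closest guides are the two measured steps that also swap the group on this oxygen. One is an at least 1.4-fold higher number from compound 2 to compound 3 (0.15 log units; that floor lies within the scatter) and the other is a step that the two limits leave unreadable from compound 1 to compound 3 as its size cannot be read. A third step comes from the fact that compounds 1 and 2 differ only in the configuration as drawn and it is an at least 1.4-fold lower number from compound 1 to compound 2 (0.15 log units; that floor lies within the scatter) with no change in the groups themselves. None of these steps is shown to go beyond the scatter, so a change of group on this oxygen has not yet been seen to move the number clearly. No step beyond the scatter is therefore expected in this assay and no direction can be favoured. The estimated step is an at least 1.1-fold lower number from compound 3 to compound 4 (0.04 log units; that floor lies within the scatter) and it may not be readable, since compound 4 could also return only a limit. For compound 4 the expected value is 18000 nM with an estimated range from 8000 nM to 40000 nM as its likely span.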

Compound 4, half-maximal inhibitory concentration: 13500 nM
Compound 4: middle estimate off by 1.3-fold (0.12 log units), on the high side; the range from low to high includes it.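

In this assay compound 4 gives 13500 nM, so a group with 0 hydrogen-bond donors and 0 hydrogen-bond acceptors on this oxygen still gives a readable number, and the hydroxyl of compound 2 is not required for one. Benzyl and the 4-hydroxycyclohexyl group of compound 2 cannot be told apart here, with a 1.0-fold lower number from compound 2 to compound 4 (0.02 log units; within the scatter). The swaps from the two compounds that give only a limit show an at least 1.4-fold lower number from compound 3 to compound 4 (0.17 log units; that floor lies within the scatter) and an at least 1.4-fold lower number from compound 1 to compound 4 (0.17 log units; that floor lies within the scatter), so this position has now taken three different kinds of group without any change shown to go beyond the scatter.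

As far as these compounds go, the step between compound 1 and compound 3 cannot be read, and how far the other steps from these two compounds truly reach stays open, since each of them gives only a limit: the limit of > 20000 nM in this assay, at which 2 of the 4 values shown sit. Also open is whether a much smaller group on this oxygen, such as methyl, or a group of another kind, such as a carboxylic acid or a longer chain ending in an amine, would move the number clearly in either direction.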